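The source may report more compounds than this note shows. Statements on the series, on what has been measured and on what is new or still open speak of the compounds shown alone.

Measured compounds:
compound 1 `N/C(=N\NC(=S)N1CCCCCC1)c1ccccn1`: 740 nM
compound 2 `N/C(=N\NC(=S)N1CCSCC1)c1ccccn1`: 760 nM
compound 3 `N/C(=N\NC(=S)N1CCSCC1)c1ccc(F)cn1`: 900 nM

In a functional assay on A-375 cells (Homo sapiens) for cytotoxicity, read by MTT assay, with a stated time of 72 h (on this read-out lower numbers stand for stronger inhibition and higher numbers for weaker inhibition), compound 1 gives 740 nM, compound 2 gives 760 nM and compound 3 gives 900 nM; all three lie within the scatter of one another. The difference between the cores of compound 1 and compound 2 is not broken down here. Compound 3 arises from compound 2 by fluoro in place of hydrogen on an aromatic carbon, a change that produced a 1.2-fold higher number from compound 2 to compound 3 (0.07 log units; within the scatter). Compound 4 `N/C(=N\NC(=S)N1CCCCCC1)c1ccc(F)cn1`, not yet measured, arises from compound 1 by the same kind of change, (fluoro in place of hydrogen on an aromatic carbon), at a place described in the same words. Going by the values given here, since the one measured instance of this change stayed within the scatter, the step is expected to be a 1.2-fold higher number from compound 1 to compound 4 (0.08 log units; within the scatter) in this assay. Compound 4 is therefore estimated at 880 nM, with a likely range from 500 nM to 1600 nM.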

Compound 4, half-maximal inhibitory concentration: 960 nM
Estimate against measurement, compound 4: 1.1-fold (0.04 log units) below; low and high end bracket the measured number.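

In this assay, fluoro in place of hydrogen on an aromatic carbon gives a 1.3-fold higher number from compound 1 to compound 4 (0.11 log units; within the scatter), and this step can be set beside the earlier one on the other core: the same change on two cores in this assay, a 1.2-fold higher number (0.07 log units; within the scatter) from compound 2 to compound 3 and a 1.3-fold higher number (0.11 log units; within the scatter) from compound 1 to compound 4, 1.1-fold (0.04 log units) apart, within the scatter of two such steps. The change therefore carried from one core to the other without a difference between the two steps that could be told from the scatter. Going by these compounds alone, as both steps themselves lie within the scatter, this shows only that the change left the number unmoved on these two cores, not that it would do so on any other core.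

The compounds shown leave open whether chloro, methoxy or an amine at the same place would give a step beyond the scatter. They also leave open how fluoro would behave elsewhere on the aromatic ring.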